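Propyl to cyano on the amine carbon: compound 3

The compounds below may be only part of what the source reports. "The series", "measured", "known", "first", "only" and "open" are said of these compounds alone.

Going by the values given here, in an assay on isolated protein for inhibition of Amine oxidase [flavin-containing] A (Homo sapiens), read by fluorescence and Amplex Red, with a stated time of 15 min, tested at 50 uM (a lower number here means less inhibition, a higher number more inhibition at the concentration tested (going by the name of the read-out)), compound 2 `C#CCN(CCCC)Cc1cn(-c2cc(NC(=S)NCC)ncn2)cn1` gives 2.43%, which puts it at the top of the two numbers measured so far, though the other number is within the scatter of it: compound 1 `C#CCN(CCC)Cc1cn(-c2cc(NC(=S)NCC)ncn2)cn1` gives 1.76%, and the step of a number 0.7 percentage points higher from compound 1 to compound 2 (within the scatter). Both numbers lie close to the floor of the read-out.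

Compound 3 `C#CCN(CC#N)Cc1cn(-c2cc(NC(=S)NCC)ncn2)cn1` differs from compound 2 by cyano in place of propyl on a saturated chain carbon bound to an amine nitrogen. Among the compounds with values here, the only measured step, a number 0.7 percentage points higher from compound 1 to compound 2 (within the scatter), altered the same propyl chain and left the number flat, so it bears on the present change only loosely; no measured step exchanges the chain for a cyano group. With both measured numbers at the floor, the expectation is a step of a number 0.6 percentage points higher from compound 2 to compound 3 (within the scatter), that is, none beyond the scatter. Compound 3 is therefore estimated at 3%, with a range from 0% to 14%.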

Compound 3, a percentage reported as inhibition, at one concentration (the size of the read-out at that concentration, not a potency): 2.01%
The estimate for compound 3 lay 1 percentage points above the measured number; the range from low to high includes it.
By their numbers in this assay, from the lowest: compounds 1, 3 and 2 (each within the scatter of the next).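

On a saturated chain carbon bound to an amine nitrogen, cyano in place of propyl gives a number 0.4 percentage points lower from compound 2 to compound 3 (within the scatter) in this assay, and cyano in place of ethyl gives a number 0.3 percentage points higher from compound 1 to compound 3 (within the scatter). The earlier compounds shown here showed only that lengthening the saturated chain left the number flat; these steps show the same for an exchange of the chain for a cyano group, which brings in a triple bond and a hydrogen-bond acceptor. No supporting measurement bears on this result, and the flat numbers remain unexplained.

Going by these compounds, all three numbers lie close to the floor of the read-out, so it remains open whether any group at this place can raise the inhibition. An amine, a carboxylic acid or a phenyl ring on this carbon would put that question to a different kind of group.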